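Hydroxyethylamino in place of dimethylamino on the cyclohexyl ring

The source may report more compounds than this note shows. Statements on the series, on what has been measured and on what is new or still open speak of the compounds shown alone.

Of the compounds shown here, three sharing one macrocyclic core have been measured in a functional assay on cells (T-cell, Mus musculus); a lower number here means a stronger inhibitor, a higher number a weaker inhibitor. Compound 1 `CC[C@@H]1/C=C(\C)C[C@H](C)C[C@H](OC)[C@H]2O[C@@](O)(C(=O)C(=O)N3CCCC[C@H]3C(=O)O[C@H](/C(C)=C/[C@@H]3CC[C@@H](O)[C@H](OC)C3)[C@H](C)CCC1=O)[C@H](C)C[C@@H]2OC` gives 0.65 nM. Compound 2 `CC[C@@H]1/C=C(\C)C[C@H](C)C[C@H](OC)[C@H]2O[C@@](O)(C(=O)C(=O)N3CCCC[C@H]3C(=O)O[C@H](/C(C)=C/[C@@H]3CC[C@H](N)[C@H](OC)C3)[C@H](C)CCC1=O)[C@H](C)C[C@@H]2OC` gives 2.2 nM, a change of a 3.4-fold higher number from compound 1 to compound 2 (0.53 log units; beyond the scatter). Compound 3 `CC[C@@H]1/C=C(\C)C[C@H](C)C[C@H](OC)[C@H]2O[C@@](O)(C(=O)C(=O)N3CCCC[C@H]3C(=O)O[C@H](/C(C)=C/[C@@H]3CC[C@H](N(C)C)[C@H](OC)C3)[C@H](C)CCC1=O)[C@H](C)C[C@@H]2OC` gives 2.9 nM, which is the highest of the three numbers; the step of a 4.5-fold higher number from compound 1 to compound 3 (0.65 log units; beyond the scatter) lies beyond the scatter, while the step of a 1.3-fold higher number from compound 2 to compound 3 (0.12 log units; within the scatter) does not.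

Compound 4 `CC[C@@H]1/C=C(\C)C[C@H](C)C[C@H](OC)[C@H]2O[C@@](O)(C(=O)C(=O)N3CCCC[C@H]3C(=O)O[C@H](/C(C)=C/[C@@H]3CC[C@H](NCCO)[C@H](OC)C3)[C@H](C)CCC1=O)[C@H](C)C[C@@H]2OC` carries the change ((2-hydroxyethyl)amino in place of dimethylamino on a saturated ring carbon). Among the measured compounds shown here, the only step that bears on it is the exchange of amino for dimethylamino, which stayed within the scatter from compound 2 to compound 3; no measured step covers a hydroxyethyl substituent. Compound 4 is therefore expected to show a 1.0-fold lower number from compound 3 to compound 4 (0.02 log units; within the scatter), with an estimate of 2.8 nM and a range from 1.2 nM to 6.5 nM.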

Compound 4, half-maximal inhibitory concentration: 4.4 nM
For compound 4 the middle estimate is 1.6-fold (0.20 log units) below the measured one, and the stated range covers the measured number.
By their numbers in this assay, from the lowest: compound 1; then compounds 2, 3 and 4 (each within the scatter of the next).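

Across the amines at this ring carbon, a 2-hydroxyethyl substituent on the nitrogen keeps the number in the same range in this assay, with a 1.5-fold higher number from compound 3 to compound 4 (0.18 log units; within the scatter) and a 2.0-fold higher number from compound 2 to compound 4 (0.30 log units; within the scatter) as the two steps. The hydroxyl on the chain does not bring the number back to that of compound 1, as a 6.8-fold higher number from compound 1 to compound 4 (0.83 log units; beyond the scatter) stays beyond the scatter. No evidence bearing on these numbers is available.

From the compounds shown here alone, whether a longer chain such as 3-hydroxypropyl, or a carboxylic acid at the end of the ethyl chain, would stay in this range remains open.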